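The compounds below may be only part of what the source reports. "The series", "measured", "known", "first", "only" and "open" are said of these compounds alone.

Measured compounds: compound 1 `Oc1ccc(-c2cc(-c3ccccc3)nc(-c3ccccc3Cl)c2)cc1`, 5460 nM; compound 2 `Oc1ccc(-c2cc(-c3ccco3)nc(-c3ccccc3Cl)c2)cc1`, 5480 nM; compound 3 `Oc1ccc(-c2cc(-c3ccncc3)nc(-c3ccccc3Cl)c2)cc1`, "not determined" (no result reported).

For the measured compounds named here, in a functional assay on T47D cells (Homo sapiens) for cytotoxicity, read by CCK-8 assay and cell counting, with a stated time of 2 days (a lower number here means a stronger inhibitor, a higher number a weaker inhibitor), compound 1 gives 5460 nM, one of only two numbers in the set, and compound 2 gives 5480 nM. The step of a 1.0-fold higher number from compound 1 to compound 2 (0.00 log units; within the scatter) does not separate the two. Compound 3 has no number in this assay. Compound 4 `Oc1ccc(-c2cc(-c3ccccc3)nc(-c3cccc(Cl)c3)c2)cc1` differs from compound 1 by 3-chlorophenyl in place of 2-chlorophenyl on an aromatic carbon. Going by the values given here, no measured step touches the chlorophenyl group; the one step available alters the phenyl group and shows no shift, so it gives no direction for the present change. A step of a 1.1-fold lower number from compound 1 to compound 4 (0.04 log units; within the scatter) is therefore expected, within the scatter. Compound 4 is estimated at 5000 nM, with a range of 1500 nM to 16000 nM.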

Compound 4, half-maximal inhibitory concentration: 4790 nM
For compound 4 the middle estimate is 1.0-fold (0.02 log units) above the measured one; the measured number falls inside the stated range.
By their numbers in this assay, from the lowest: compounds 4, 1 and 2 (each within the scatter of the next).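

In this assay, for the compounds shown here, 3-chlorophenyl in place of 2-chlorophenyl on the aromatic carbon next to the ring nitrogen gives a 1.1-fold lower number from compound 1 to compound 4 (0.06 log units; within the scatter), so the first look at this position shows no readable difference between these two chlorophenyl groups. No measurement is available that bears on this result.

Still open, going by these compounds, is whether 4-chlorophenyl or unsubstituted phenyl at this position would give a number beyond the scatter. Also open, on these data alone, is whether a methoxy group or an amine on this ring would do so.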